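A few compounds are considered here, and "the series" means these few. Any claim that something is new, unique, unknown or untested is made for them only; others in the source may bear on it.

Measured compounds:
Compound 1: `O=S(=O)(Nc1ccc(-c2nc3ccccc3o2)cc1)c1cccc(F)c1`, in an assay on cells for inhibition of HSP60/HSP10 (Homo sapiens), with a stated time of 60 min (a higher number here means a weaker inhibitor, a lower number a stronger inhibitor), compound 1 gives 71000 nM.
Compound 2: `O=S(=O)(Nc1ccc2oc(-c3ccccc3)nc2c1)c1ccc(Cl)s1`, in this assay compound 2 gives 70000 nM.

Among the measured compounds shown here, compound 1 stands with one of only two numbers, and the gap between its number and that of compound 2 lies within the usual scatter of repeated measurements, so neither compound can be called the stronger or the weaker inhibitor. Both values sit in a region that marks weak inhibition in this assay.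

Compound 3 is `Cc1ccccc1S(=O)(=O)Nc1ccc(-c2nc3ccccc3o2)cc1`. It differs from compound 1 in one place: 2-methylphenyl in place of 3-fluorophenyl on a sulfonyl sulfur. The sulfonamide nitrogen and the core of compound 1 stay as they are; only the aryl group on the sulfonyl sulfur changes. For the measured compounds named here, no pair of measured compounds isolates a change of this kind, so there is no measured step to lean on. Given that both measured compounds cluster in the same weak region, the step from compound 1 to compound 3 is expected to be small, in either direction, and within the scatter, which is what a 1.1-fold lower number from compound 1 to compound 3 (0.04 log units; within the scatter) expresses. Compound 3 is therefore estimated to give about 65000 nM in this assay, expected to fall between 20000 nM and 200000 nM.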

Compound 3, half-maximal inhibitory concentration: 85000 nM
Estimate against measurement, compound 3: 1.3-fold (0.12 log units) below; measured number inside the range.
By their numbers in this assay, from the lowest: compounds 2, 1 and 3 (each within the scatter of the next).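

In this assay, among the compounds shown here, the exchange of 3-fluorophenyl for 2-methylphenyl on a sulfonyl sulfur gives a 1.2-fold higher number from compound 1 to compound 3 (0.08 log units; within the scatter), and this pair offers the first direct reading of a change at this position. Both groups are a six-membered aromatic ring of carbon only, with no hydrogen-bond donors or acceptors and no net charge, so the pair shows that this one exchange between closely matched groups leaves no difference that can be read in this assay, but a single pair sets no general pattern. No measurement offered here accounts for the two compounds reading alike.

Still open, on these data alone, is whether a group of a different kind on the sulfonyl sulfur, such as an aryl ring carrying a carboxylic acid or an amine, would give a number beyond the scatter of compound 1. As far as these compounds go, it also remains open whether the same exchange of aryl groups would read alike on the core of compound 2, which carries a different arrangement of the shared parts.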